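Diethylamino in place of ethyl on a pyrimidine side chain

The source may hold more compounds than are shown below. What is called first, only, known or untested is meant among the compounds shown, and "the series" means these compounds.

Three compounds of one shared core have been measured in an assay on HEK293 cells for agonist activity at Toll-like receptor 8 (Homo sapiens), read by spectrophotometry; a higher number here means that more compound is needed for the effect, a lower number that less compound is needed:

Compound 1, `CCCCNc1nc(N)nc(C)c1CCCCO`, gives 1310 nM.
Compound 2, `CCCCNc1nc(N)nc(C)c1CCCN(C)C`, gives 126 nM.
Compound 3, `CCCCCc1c(C)nc(N)nc1NCCCC`, gives 1220 nM.

Among these three numbers compound 3 stands second highest. Its nearest neighbour is compound 1, and the two are within the usual scatter of each other, as a 1.1-fold lower number from compound 1 to compound 3 (0.03 log units; within the scatter) shows; its furthest is compound 2, reached by a 9.7-fold higher number from compound 2 to compound 3 (0.99 log units; beyond the scatter).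

Compound 4, `CCCCNc1nc(N)nc(C)c1CCCN(CC)CC`, has not yet been measured. It differs from compound 3 by diethylamino in place of ethyl on a saturated chain carbon, three bonds along the chain from an aromatic carbon.

Among the compounds with values here, one measured step bears directly on this change: a 9.7-fold higher number from compound 2 to compound 3 (0.99 log units; beyond the scatter), where the same chain position carried a dimethylamino group instead. A second step points the same way: a 10-fold lower number from compound 1 to compound 2 (1.02 log units; beyond the scatter). Both show that a dialkylamino group at this position goes with a markedly lower number than hydroxy or ethyl. Compound 4 is therefore expected to follow the reverse of a 9.7-fold higher number from compound 2 to compound 3 (0.99 log units; beyond the scatter), a step estimated as an 8.1-fold lower number from compound 3 to compound 4 (0.91 log units; beyond the scatter). The estimate for compound 4 in this assay is 150 nM, with a range from 50 nM to 500 nM.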

Compound 4, half-maximal effective concentration: 254 nM
For compound 4 the middle estimate is 1.7-fold (0.23 log units) below the measured one; low and high end bracket the measured number.
By their numbers in this assay, from the lowest: compounds 2 and 4 (each within the scatter of the next); then compounds 3 and 1 (each within the scatter of the next).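

In this assay, the lower number seen with dimethylamino is not confined to that one amine: diethylamino at the same place, on a saturated chain carbon three bonds along the chain from an aromatic carbon, gives a 4.8-fold lower number from compound 3 to compound 4 (0.68 log units; beyond the scatter) and a 5.2-fold lower number from compound 1 to compound 4 (0.71 log units; beyond the scatter). Exchanging one amine for the other makes no difference that can be told apart, as a 2.0-fold higher number from compound 2 to compound 4 (0.30 log units; within the scatter) lies within the scatter. Nothing available explains these steps.

The compounds shown leave open whether a primary amine or dipropylamino at this place would go with the same lower number as dimethylamino and diethylamino. They also leave open how a longer or shorter chain between the shared core and the amine would change the number.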